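This account rests on a few compounds, and the source may have more. Where it says the series, first, only, none or still open, it means among the compounds named here.

Measured so far in a functional assay (FL5.12 cells, Mus musculus) with Apoptosis regulator Bcl-2 (Homo sapiens) as the target; on this read-out higher numbers stand for an effect only at larger amounts of compound and lower numbers for an effect already at smaller amounts:
- compound 1 `CCCCCC1(OC)CCN(c2ccc(C(=O)NS(=O)(=O)c3ccc(N[C@H](CCN(C)C)CSc4ccccc4)c([N+](=O)[O-])c3)cc2)CC1`: 3000 nM
- compound 2 `COC1(Cc2ccccc2C)CCN(c2ccc(C(=O)NS(=O)(=O)c3ccc(N[C@H](CCN(C)C)CSc4ccccc4)c([N+](=O)[O-])c3)cc2)CC1`: 200 nM
- compound 3 `CN(C)CC[C@H](CSc1ccccc1)Nc1ccc(S(=O)(=O)NC(=O)c2ccc(N3CCC(=Cc4ccc(F)cc4)CC3)cc2)cc1[N+](=O)[O-]`: 600 nM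

Compound 3 holds the second highest number of the three: compound 2 sits lower, compound 1 sits higher, both gaps beyond the scatter. Among the measured compounds shown here, the only single-point step recorded, a 15-fold lower number from compound 1 to compound 2 (1.18 log units; beyond the scatter), concerns an exchange of butyl for 2-methylphenyl on a saturated chain carbon.

Compound 4 `CN(C)CC[C@H](CSc1ccccc1)Nc1ccc(S(=O)(=O)NC(=O)c2ccc(N3CCC(=Cc4ccccn4)CC3)cc2)cc1[N+](=O)[O-]` differs from compound 3 by pyridin-2-yl in place of 4-fluorophenyl on a double-bonded chain carbon bound to a double-bonded ring carbon. For the measured compounds named here, no measured step covers an aryl-for-aryl swap at this double-bonded position, so the recorded step gives no direct guide. With nothing to indicate a shift, compound 4 is expected to stay near compound 3 in this assay, a step of no change at the digits printed from compound 3 to compound 4 (within the scatter), within the scatter. The estimate for compound 4 is 600 nM, with a range from 250 nM to 1500 nM.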

Compound 4, half-maximal effective concentration: 1380 nM
Compound 4: middle estimate off by 2.3-fold (0.36 log units), on the low side; measured number inside the range.
By their numbers in this assay, from the lowest: compound 2; then compound 3; then compound 4; then compound 1.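

At the double-bonded chain carbon bound to a double-bonded ring carbon, the choice of aromatic ring moves the number in this assay: pyridin-2-yl in place of 4-fluorophenyl gives a 2.3-fold higher number from compound 3 to compound 4 (0.36 log units; beyond the scatter). Among the compounds shown here, this step is modest and just beyond the scatter, and it is the first reading at this position. Nothing available explains the shift.

The change removes the fluorine and brings in the ring nitrogen together, so their shares stay unseparated. Unsubstituted phenyl and pyridin-4-yl at this position would divide the step.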